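The compounds below may be only part of what the source reports. "The series", "measured", "known", "first", "only" and "open" are said of these compounds alone.

Values in a functional assay on KBVIN cells (Homo sapiens) for antiproliferative activity, read by sulforhodamine B assay, with a stated time of 3 days; a higher number here means a weaker inhibitor of growth, a lower number a stronger inhibitor of growth:
- compound 1 `COc1ccc(NC(=O)c2cccc(Nc3ncc(F)c(Nc4ccc(F)cc4)n3)c2)cc1`: 15700 nM
- compound 2 `O=C(c1cccc(Nc2ncc(F)c(Nc3ccc(F)cc3)n2)c1)N1CCCCC1`: 13800 nM
- compound 3 `CN1CCC(C(=O)Nc2cccc(Nc3ncc(F)c(Nc4ccc(F)cc4)n3)c2)CC1`: 11900 nM

Compound 3 stands level with the other two compounds, and no ranking of the three is possible. The measured steps are a 1.1-fold lower number from compound 1 to compound 2 (0.06 log units; within the scatter), a 1.3-fold lower number from compound 1 to compound 3 (0.12 log units; within the scatter) and a 1.2-fold lower number from compound 2 to compound 3 (0.06 log units; within the scatter), and all lie within the scatter.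

The next change leads to compound 4 `COCC(=O)Nc1cccc(Nc2ncc(F)c(Nc3ccc(F)cc3)n2)c1`: methoxymethyl in place of 1-methylpiperidin-4-yl on a carbonyl carbon. In words, methoxymethyl stands in place of 1-methylpiperidin-4-yl on a carbonyl carbon. Among the compounds with values here, the steps that bear on this most closely are a 1.3-fold lower number from compound 1 to compound 3 (0.12 log units; within the scatter) and a 1.2-fold lower number from compound 2 to compound 3 (0.06 log units; within the scatter), since both end at the ((1-methylpiperidin-4-yl)carbonyl)amino group that is altered here. Neither moved the number beyond the scatter. All three measured compounds carry a ring in the varied group, so an open chain such as methoxymethyl has not been tested, and the range is kept wide.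

No step beyond the scatter is expected, in either direction, and the estimated step is a 1.1-fold higher number from compound 3 to compound 4 (0.04 log units; within the scatter).

For compound 4 the expected value is 13000 nM, with an estimated range of 7000 nM to 24000 nM.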

Compound 4, concentration for 50% growth inhibition: 3940 nM
Compound 4: middle estimate off by 3.3-fold (0.52 log units), on the high side; the whole stated range lies above it.
By their numbers in this assay, from the lowest: compound 4; then compounds 3, 2 and 1 (each within the scatter of the next).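

In this assay, the group on this carbonyl carbon proves able to move the number: a 3.0-fold lower number from compound 3 to compound 4 (0.48 log units; beyond the scatter) with methoxymethyl, an open chain with no ring, in place of 1-methylpiperidin-4-yl, whereas the steps among compound 1, compound 2 and compound 3 all stayed within the scatter. The open chain also separates from the other two groups, with a 3.5-fold lower number from compound 2 to compound 4 (0.54 log units; beyond the scatter) and a 4.0-fold lower number from compound 1 to compound 4 (0.60 log units; beyond the scatter), which gives compound 4 the lowest number of the four. Nothing measured here accounts for this step.

On these data alone, with compound 4 alone, it stays open whether the lower number goes with the loss of the ring, the smaller group or the oxygen in the chain. Propyl, a longer chain such as 2-methoxyethyl, or an open-chain amine such as dimethylaminomethyl on the same carbonyl carbon would help to separate these.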